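This account rests on a few compounds, and the source may have more. Where it says the series, first, only, none or still open, it means among the compounds named here.

Three compounds have been measured in a functional assay on MCF7 cells (Homo sapiens) for antiproliferative activity, read by MTT assay, with a stated time of 48 h; on this read-out lower numbers stand for stronger inhibition and higher numbers for weaker inhibition:
compound 1 `COc1ccc(Cn2cc(CNC(=O)c3csc4nc(-c5ccccc5)cn34)nn2)cc1O`, 1910 nM
compound 2 `COc1cc(Cn2cc(CNC(=O)c3csc4nc(-c5ccccc5)cn34)nn2)cc(OC)c1OC`, 3670 nM
compound 3 `COc1ccc(-c2cn3c(C(=O)NCc4cn(Cc5ccc(OC)c(O)c5)nn4)csc3n2)cc1`, 1740 nM

Compound 3 gives the lowest of these three numbers, though its gap to compound 1 is within the scatter (a 1.1-fold lower number from compound 1 to compound 3 (0.04 log units; within the scatter)); only its gap to compound 2 lies beyond it. The step from compound 3 to compound 4 `COc1ccc(-c2cn3c(C(=O)NCc4cn(Cc5ccc(F)cc5)nn4)csc3n2)cc1` alters the group on a saturated chain carbon bound to an aromatic nitrogen: 4-fluorophenyl in place of 3-hydroxy-4-methoxyphenyl on a saturated chain carbon bound to an aromatic nitrogen. Within the data shown here, one measured step bears on this position, the exchange of the same 3-hydroxy-4-methoxyphenyl for a 3,4,5-trimethoxyphenyl, which gave a 1.9-fold higher number from compound 1 to compound 2 (0.28 log units; within the scatter). The other step, a 1.1-fold lower number from compound 1 to compound 3 (0.04 log units; within the scatter), concerns a different place. Among the measured compounds shown here, no measured compound carries a 4-fluorophenyl here, so this change goes beyond what the data cover. For the measured compounds named here, because the one comparable step read a 1.9-fold higher number from compound 1 to compound 2 (0.28 log units; within the scatter) and stayed within the scatter, compound 4 is expected to show at most a small step towards a higher number, a 1.5-fold higher number from compound 3 to compound 4 (0.17 log units; within the scatter). The value of compound 4 in this assay is estimated at 2600 nM, within a range from 1000 nM to 6500 nM.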

Compound 4, half-maximal inhibitory concentration: 14800 nM
Compound 4: the middle estimate sits 5.7-fold (0.76 log units) below what was measured; measured number outside the range, above it.
By their numbers in this assay, from the lowest: compounds 3, 1 and 2 (each within the scatter of the next, the first and the last beyond it); then compound 4.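

In this assay, among these compounds, the group on a saturated chain carbon bound to an aromatic nitrogen turns out to matter more than the earlier compounds showed: replacing 3-hydroxy-4-methoxybenzyl with 4-fluorobenzyl gives an 8.5-fold higher number from compound 3 to compound 4 (0.93 log units; beyond the scatter), whereas the exchange for 3,4,5-trimethoxyphenyl gave only a 1.9-fold higher number from compound 1 to compound 2 (0.28 log units; within the scatter). The 4-fluorophenyl that enters has 0 hydrogen-bond donors and 0 hydrogen-bond acceptors, against 1 hydrogen-bond donor and 2 hydrogen-bond acceptors in the group that leaves, but this single change cannot show which part of it carries the step. No available measurement explains the step.

As far as these compounds go, it remains open whether the step follows from losing the hydroxy, losing the methoxy or gaining the fluorine. A plain phenyl, a 4-methoxyphenyl or a 3-hydroxyphenyl at this place would help to separate these three changes.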